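A few compounds are considered here, and "the series" means these few. Any claim that something is new, unique, unknown or untested is made for them only; others in the source may bear on it.

Compound 1 `COc1cccc(OC)c1C(=O)Nc1c[nH]nc1C(=O)NC1CCN(Cc2ccccc2)C1` gives 38000 nM in an ADME assay on MRC5 cells (Homo sapiens) for inhibition, with a stated time of 72 h; on this read-out higher numbers stand for an effect only at larger amounts of compound and lower numbers for an effect already at smaller amounts.
Compound 2 `COc1cccc(OC)c1C(=O)Nc1c[nH]nc1C(=O)N[C@H]1CC[C@H](O)CC1` gives 34000 nM in this assay.
Compound 3 `CO[C@H]1CC[C@H](NC(=O)c2n[nH]cc2NC(=O)c2ccc(N3CCCC3)cc2)CC1` gives > 50000 nM in this assay, which is a limit of the assay and not a number.

Of the two compounds with a number in this assay, compound 2 carries the lower one, yet compound 1 lies so close that the two cannot be told apart within the usual scatter. For compound 3 only a limit is reported (the limit of > 50000 nM in this assay, at which 1 of the 3 values shown sits), so it says nothing about where the true number lies.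

Compound 4 `COc1cccc(OC)c1C(=O)Nc1c[nH]nc1C(=O)Nc1ccccc1` has not yet been measured. It differs from compound 2 in a single place: phenyl in place of 4-hydroxycyclohexyl on an amide-type nitrogen. The rest of the molecule, including the shared core and the amide-type nitrogen carrying the new group, is unchanged.

Among the measured compounds shown here, no step between two measured compounds is available, so the size of this move cannot be read off from the data and must be estimated. I expect a modest step toward a lower number in this assay, meaning an effect already at somewhat smaller amounts of compound, with a fair chance that the change stays within the scatter. Compound 4 is expected to give about 20000 nM, with a range from 8000 nM to 50000 nM. This estimate means a step of a 1.7-fold lower number from compound 2 to compound 4 (0.23 log units; within the scatter).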

Compound 4, half-maximal effective concentration: > 50000 nM
Compound 4 was reported as a limit; the forecaster's own chance of this, stated with the estimate: 20%; middle value at least 2.5-fold (0.39 log units) away from the limit.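

Among the compounds shown here, replacing 4-hydroxycyclohexyl with phenyl on the amide-type nitrogen gives the first direct comparison at this position in this assay: an at least 1.4-fold higher number from compound 2 to compound 4 (0.16 log units; that floor lies within the scatter). On these data alone, the change therefore brings no move toward a lower number, although the step's floor alone cannot show a real rise, and its true size remains unknown. The reading for compound 4 is a limit of the assay, not a number, and such limits now make up a sizeable share of the results: the limit of > 50000 nM in this assay, at which 2 of the 4 values shown sit.

The swap changes both the ring type and the hydroxyl group at once, so these compounds cannot show which of the two matters. As far as these compounds go, a plain cyclohexyl group or a 4-hydroxyphenyl group would separate them, while an amine or a carboxylic acid on the ring remains unexplored here.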